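This account rests on a few compounds, and the source may have more. Where it says the series, first, only, none or still open, it means among the compounds named here.

Measured so far in an ADME assay on MDCK cells (Canis lupus familiaris) for cytotoxicity, read by MTT assay, with a stated time of 24 h; on this read-out lower numbers stand for higher toxicity in this test and higher numbers for lower toxicity in this test:
Compound 1 `O=[N+]([O-])c1ccc(S(=O)(=O)NCc2ccoc2)cc1` gives > 236000 nM (a limit)
Compound 2 `O=[N+]([O-])c1ccc(S(=O)(=O)NCc2ccsc2)cc1` gives 139000 nM

The entry for compound 1 is a limit and not a number. Among the compounds with values here, compound 2 therefore holds the only true number. Compound 3 `O=[N+]([O-])c1ccc(S(=O)(=O)NCc2ccc(Cl)s2)cc1` differs from compound 2 by 5-chlorothiophen-2-yl in place of thiophen-3-yl on a saturated chain carbon bound to a sulfonamide nitrogen, with 5-chlorothiophen-2-yl in place of thiophen-3-yl. Within the data shown here, the only measured step is an at least 1.6-fold lower number from compound 1 to compound 2 (0.22 log units; that floor lies within the scatter), also a ring exchange at this place. On that single step, no change beyond the scatter is expected in this assay. The expected step is a 1.3-fold lower number from compound 2 to compound 3 (0.10 log units; within the scatter). For compound 3 the estimated value is 110000 nM, with an expected range of 40000 nM to 240000 nM.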

Compound 3, half-maximal cytotoxic concentration: 128000 nM
The estimate for compound 3 lay 1.2-fold (0.07 log units) below the measured number; the range from low to high includes it.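

On a saturated chain carbon bound to a sulfonamide nitrogen, 5-chlorothiophen-2-yl in place of thiophen-3-yl gives in this assay a 1.1-fold lower number from compound 2 to compound 3 (0.04 log units; within the scatter), so a ring carrying chlorine, with a different point of attachment, stays within the scatter of thiophen-3-yl. Against furan-3-yl the same ring gives an at least 1.8-fold lower number from compound 1 to compound 3 (0.26 log units; that floor lies within the scatter), which is only a floor. Compound 1 holds a limit and not a number: the limit of > 236000 nM in this assay, at which 1 of the 3 values shown sits.

Going by these compounds, whether the furan-3-yl and thiophen ring compounds truly differ stays open. So does whether an amine, a carboxylic acid or a longer chain at this place would move the number beyond the scatter.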